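Trimethoxybenzoyl pyrroles: changing the aryl group on the core

This account rests on a few compounds, and the source may have more. Where it says the series, first, only, none or still open, it means among the compounds named here.

Measured compounds:
- compound 1, `COc1cc(C(=O)c2cn(-c3ccccc3Cl)cc2-c2ccccc2)cc(OC)c1OC`; in a functional assay on MCF7 cells (Homo sapiens) for cytotoxicity, read by MTT assay, with a stated time of 96 h (on this read-out lower numbers stand for stronger inhibition and higher numbers for weaker inhibition), compound 1 gives 1800 nM
- compound 2, `COc1cc(C(=O)c2cn(-c3ccccc3)cc2-c2ccccc2Br)cc(OC)c1OC`; in this assay compound 2 gives 190 nM

Compound 2 holds the lowest number of the two measured compounds; the nearest, compound 1, sits beyond the usual scatter from it. Among the compounds with values here, no step between single-change pairs of measured compounds is available, so nothing here shows how a change on the aryl group of the core of compound 2 plays out.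

Compound 3, `COc1ccc(Br)cc1-c1cn(-c2ccccc2)cc1C(=O)c1cc(OC)c(OC)c(OC)c1`, is the next compound to test. It differs from compound 2 in one place: 5-bromo-2-methoxyphenyl in place of 2-bromophenyl on an aromatic carbon.

Within the data shown here, with no measured step to guide this change, only a modest move is expected, toward weaker inhibition if any, and the step from compound 2 to compound 3 in this assay is estimated at a 2.4-fold higher number from compound 2 to compound 3 (0.37 log units; beyond the scatter). Compound 3 is therefore expected to give 450 nM in this assay, within the range 120 nM to 2000 nM.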

Compound 3, half-maximal inhibitory concentration: 2200 nM
Compound 3: the middle estimate sits 4.9-fold (0.69 log units) below what was measured, outside the stated range (above it).
By their numbers in this assay, from the lowest: compound 2; then compounds 1 and 3 (each within the scatter of the next).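

In this assay, within the data shown here, placing 5-bromo-2-methoxyphenyl in place of 2-bromophenyl on this aromatic carbon gives a 12-fold higher number from compound 2 to compound 3 (1.06 log units; beyond the scatter) and supplies the only single-change step so far. The size of that step shows that the read-out is sensitive to the aryl group at this position, two ring bonds from the ring nitrogen, and that this particular replacement moves toward weaker inhibition. Nothing available explains why the number rises at this position.

The change brings in a methoxy group and also alters where the bromine sits on the aryl ring, so the compounds shown do not separate these two parts of the step. Open too, from the compounds shown here alone, is how 2-methoxyphenyl alone, or an aryl group carrying an amine or a carboxylic acid, would read on this carbon.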